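Methyl in Place of Chloro in Two Related Pairs

A few compounds are considered here, and "the series" means these few. Any claim that something is new, unique, unknown or untested is made for them only; others in the source may bear on it.

Compound 1, `COc1cc2ncnc(NNC(=S)NC(=O)c3ccc(Cl)cc3)c2cc1OC`, gives 9620 nM in a functional assay on GLC82 cells (Homo sapiens) for cytotoxicity, read by MTT assay, with a stated time of 72 h; on this read-out higher numbers stand for weaker inhibition and lower numbers for stronger inhibition.
Compound 2, `COc1cc2ncnc(NNC(=S)NC(=O)c3ccc(C)cc3)c2cc1OC`, gives 29900 nM in this assay.
Compound 3, `O=C(NC(=S)NNc1ncnc2ccccc12)c1ccccc1Cl`, gives 10800 nM in this assay.

Within the first pair the single change is methyl in place of chloro on an aromatic carbon, and it produced a 3.1-fold higher number from compound 1 to compound 2 (0.49 log units; beyond the scatter). The difference between the core of compound 1 and the core of compound 3 is not broken down here; their values stand close to each other, within the usual scatter. Compound 4, `Cc1ccccc1C(=O)NC(=S)NNc1ncnc2ccccc12`, has not yet been measured; it differs from compound 3 by methyl in place of chloro on an aromatic carbon. The two changes are the same kind of change rather than the same: in the measured pair the group sits para to a large group, whereas in compound 3 and compound 4 it sits ortho to a large group. Resting on the step from compound 1 to compound 2, a step of a 2.5-fold higher number from compound 3 to compound 4 (0.40 log units; beyond the scatter) is expected from compound 3 to compound 4 in this assay, with more room for deviation given the altered place. Compound 4 is estimated at 27000 nM, expected to lie between 12000 nM and 60000 nM.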

Compound 4, half-maximal inhibitory concentration: 13200 nM
Compound 4: the middle estimate sits 2.0-fold (0.31 log units) above what was measured; the measured number falls inside the stated range.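

In this assay, methyl in place of chloro, this time as 2-chlorophenyl to 2-methylphenyl, gave a 1.2-fold higher number from compound 3 to compound 4 (0.09 log units; within the scatter), so on this second core the change has no effect that can be told from the scatter. Set beside the first pair, the two steps cannot be separated: the same change on two cores in this assay, a 3.1-fold higher number (0.49 log units; beyond the scatter) from compound 1 to compound 2 and a 1.2-fold higher number (0.09 log units; within the scatter) from compound 3 to compound 4, 2.5-fold (0.41 log units) apart, within the scatter of two such steps. Among the compounds shown here, this shows that the series offers no firm sign of the core altering the effect of the change, but it does not show that the step carries over at the same size, as only one of the two steps lies beyond the scatter, the place of the group differs between the pairs along with the core, and two pairs are a narrow base.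

The compounds shown leave open how an amine or a carboxylic acid in place of chloro would read on either core. They also leave open how methyl in place of chloro would read with the group in the same place on both cores.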